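Series notes: from compound 3 to compound 4

The source may report more compounds than this note shows. Statements on the series, on what has been measured and on what is new or still open speak of the compounds shown alone.

Three compounds sharing one core have entries so far in a functional assay on B16 cells (Mus musculus) for antiproliferative activity, with a stated time of 72 h (on this read-out higher numbers stand for weaker inhibition and lower numbers for stronger inhibition), and only one of them carries a result. Compound 1 `Cc1cccc(CNc2ncnc3c2ncn3[C@@H]2O[C@H](CO)[C@@H](O)[C@H]2O)c1` gives > 166000 nM in this read-out, and that entry is a limit of the assay, not a number. Compound 2 `COc1cccc(CNc2ncnc3c2ncn3[C@@H]2O[C@H](CO)[C@@H](O)[C@H]2O)c1OC` stands as "not determined" (no result reported) in the same read-out. Among the compounds with values here, compound 3 `COc1ccc(CNc2ncnc3c2ncn3[C@@H]2O[C@H](CO)[C@@H](O)[C@H]2O)c(OC)c1` also stands as "not determined" (no result reported) and therefore has no single number to step from.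

Compound 4 `OC[C@H]1O[C@@H](n2cnc3c(NCc4ccc(F)c(F)c4F)ncnc32)[C@H](O)[C@@H]1O` is still to be measured. The structural change is 2,3,4-trifluorophenyl in place of 2,4-dimethoxyphenyl on a saturated chain carbon bound to a nitrogen on an aromatic ring with 2,3,4-trifluorophenyl in place of 2,4-dimethoxyphenyl on a saturated chain carbon bound to a nitrogen on an aromatic ring.

Within the data shown here, no measured step sizes this change. A modest step towards stronger inhibition is the most that is expected, and compound 4 may well return only a limit. Through the limit of > 166000 nM in this assay, at which 1 of the 3 values shown sits, compound 1 is the only anchor for this expectation.

In this assay compound 4 is expected at 100000 nM with 30000 nM as the lower end and 200000 nM as the upper end of the estimate.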

Compound 4, half-maximal inhibitory concentration: > 166000 nM
Compound 4: no number, only a limit (the forecaster's own chance of this, stated with the estimate: 55%); middle value at least 1.6-fold (0.22 log units) away from the limit.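

Within the data shown here, compound 1 and compound 4 both return a limit rather than a number in this assay, so no step between them can be read: the limit of > 166000 nM in this assay, at which 2 of the 4 values shown sit. The compounds shown leave open whether any substituent on the shared core gives a measurable inhibition here.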